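The compounds below may be only part of what the source reports. "The series", "measured", "known", "first", "only" and "open" are said of these compounds alone.

The study reports three compounds in an ADME assay on Caco-2 cells (Homo sapiens) for cytotoxicity, read by MTT assay, with a stated time of 72 h (a lower number here means that less compound is tolerated, a higher number that more compound is tolerated), and leaves a fourth open. Compound 2 `CC1(C)CCc2cc(CC3=C(c4ccc(O)cc4)[C@@](O)(C(=O)O)OC3=O)ccc2O1` carries a free carboxylic acid on its core. In this assay compound 2 reaches only a limit of the method, > 800000 nM. Compound 1 `COC(=O)[C@@]1(O)OC(=O)C(Cc2ccc3c(c2)CCC(C)(C)O3)=C1c1ccc(O)cc1` is its methyl ester; the difference is methyl in place of hydrogen on an oxygen next to a carbonyl group. In this assay compound 1 gives 278000 nM. The measured step, an at least 2.8-fold lower number from compound 2 to compound 1 (0.45 log units; beyond the scatter), therefore moves a compound off (the limit of > 800000 nM in this assay, at which 2 of the 3 values shown sit).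

Compound 3 `COC(=O)c1cc(O)cc(OC)c1Oc1c(Cl)c(C)c(Cl)c(O)c1C(=O)O` rests on another core; the difference between the core of compound 3 and that of compound 2 is not broken down here. In this assay compound 3 also reports only a limit, > 800000 nM. Compound 4 `COC(=O)c1cc(O)cc(OC)c1Oc1c(Cl)c(C)c(Cl)c(O)c1C(=O)OC` is the methyl ester of compound 3, the change being (methyl in place of hydrogen on an oxygen next to a carbonyl group). This is the same change as that from compound 2 to compound 1, at the same place, on an oxygen next to a carbonyl group whose other neighbours are the carbonyl carbon.

For compound 4 the account expects a step of an at least 2.6-fold lower number from compound 3 to compound 4 (0.42 log units; beyond the scatter). That expectation rests on the measured step of an at least 2.8-fold lower number from compound 2 to compound 1 (0.45 log units; beyond the scatter). Since compound 3 stands at a limit, the true size of the expected step is uncertain and a limit for compound 4 remains possible. Compound 4 is estimated at 300000 nM, within a range from 120000 nM to 800000 nM.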

Compound 4, half-maximal cytotoxic concentration: > 800000 nM
Compound 4 was reported as a limit; the forecaster's own chance of this, stated with the estimate: 35%; at least 2.6-fold (0.42 log units) between middle value and limit.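

In this assay compound 4 reports only a limit, > 800000 nM. Among these compounds, compound 3 also stands at a limit, so no step between compound 3 and compound 4 can be read. The compounds shown leave open whether methyl in place of hydrogen on an oxygen next to a carbonyl group changes the number on the core of compound 3 as it does on the core of compound 2.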